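The source may report more compounds than this note shows. Statements on the series, on what has been measured and on what is new or still open speak of the compounds shown alone.

Measured in an ADME assay on H9c2 cells (Rattus norvegicus) for cytotoxicity; a lower number here means a stronger inhibitor, a higher number a weaker inhibitor:

Compound 1 `CCc1ccc2nc(NC(=O)C3CC3)sc2c1`: > 50000 nM
Compound 2 `N#Cc1cc2sc(NC(=O)C3CC3)nc2cc1F`: > 50000 nM

Each of these entries is a limit of the assay, not a number. Compound 2 stands at that limit, and so does the other measured compound: the limit of > 50000 nM in this assay, at which 2 of the 2 values shown sit. Compound 3 `CCS(=O)(=O)c1cc2sc(NC(=O)C3CC3)nc2cc1F` carries ethylsulfonyl in place of cyano on an aromatic carbon, ortho to a fluoro group: ethylsulfonyl in place of cyano on an aromatic carbon. Going by the values given here, no measured step gives the size of this change, so the expectation rests on the limit of compound 2, > 50000 nM. The expected change, a number no higher from compound 2 to compound 3 (the limit leaves the size open), is none beyond the scatter in this assay. Compound 3 is estimated at 50000 nM, with an expected range from 20000 nM to 100000 nM.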

Compound 3, half-maximal inhibitory concentration: > 50000 nM
Compound 3: a limit, no number (the forecaster's own chance of this, stated with the estimate: 75%); the middle value lies on the limit itself.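

Compound 2 and compound 3 both give a limit rather than a number in this assay, so no step can be read between them: the limit of > 50000 nM in this assay, at which 3 of the 3 values shown sit.

The compounds shown leave open whether any change to the shared core would give a measurable number in this assay.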